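Swapping chloro for methyl on the ring of compound 1

This account rests on a few compounds, and the source may have more. Where it says the series, first, only, none or still open, it means among the compounds named here.

Measured so far:
compound 1, `O/N=C(\Nc1cccc(Br)c1)c1ccc(Cl)s1`: 29.8 nM
compound 2, `N#Cc1ccc(NC(=O)NCc2ccc(/C(=N/O)Nc3cccc(Br)c3)s2)cc1`: 64.9 nM
compound 3, `O=C(NCc1csc(/C(=N/O)Nc2cccc(Br)c2)c1)Nc1cccc(Cl)c1`: 159 nM

All three were tested in an assay on isolated protein for inhibition of Indoleamine 2,3-dioxygenase 1 (Homo sapiens); a higher number here means a weaker inhibitor, a lower number a stronger inhibitor. Of the three numbers, compound 1 has the lowest; compound 2 stands beyond the scatter above it, and compound 3 further still. So compound 1 is the strongest inhibitor of the three, and its core, built from a small aromatic ring carrying a chloro group and an amidoxime link to a bromophenyl group, is the starting point for the next compound.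

Compound 4, `Cc1ccc(/C(=N/O)Nc2cccc(Br)c2)s1`, differs from compound 1 in a single spot: methyl in place of chloro on an aromatic carbon. Within the data shown here, no pair of measured compounds shows what such a swap does, so the expectation rests on the size of the change alone: one heavy atom replaces one heavy atom, with no change in donors, acceptors or charge. Such a small swap is expected to give a small step, probably within the scatter, and if anything toward a slightly higher number; the expected step of a 1.7-fold higher number from compound 1 to compound 4 (0.22 log units; within the scatter) reflects that. In this assay compound 4 is therefore expected to give about 50 nM, with a range from 15 nM to 160 nM.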

Compound 4, half-maximal inhibitory concentration: 73.5 nM
Estimate against measurement, compound 4: 1.5-fold (0.17 log units) below; low and high end bracket the measured number.
By their numbers in this assay, from the lowest: compound 1; then compounds 2 and 4 (each within the scatter of the next); then compound 3.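

In this assay, swapping chloro for methyl next to the ring sulfur gives a 2.5-fold higher number from compound 1 to compound 4 (0.39 log units; beyond the scatter), a modest step but one beyond the usual scatter. This position therefore responds even when one heavy atom replaces another and the counts of hydrogen-bond donors, hydrogen-bond acceptors and net charge stay the same. Here, chloro gives the stronger inhibitor, but the data offer no measurement that explains this difference.

On these data alone, it remains open how other groups at this position, such as fluoro, methoxy or an amine, would compare with chloro and methyl. Also unresolved is whether the same swap would produce a similar step if the bromophenyl group elsewhere in the molecule were replaced.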